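A few compounds are considered here, and "the series" means these few. Any claim that something is new, unique, unknown or untested is made for them only; others in the source may bear on it.

Three compounds share one fused two-ring core and differ in the arm attached to it. Compound 1 `C=C1CC[C@H]2C(C)(C)CCC[C@]2(C)[C@H]1CC(O)c1ccoc1` carries a hydroxy-bearing chain ending in a five-membered aromatic ring with one hetero atom, and in a functional assay on SNU1 cells (Homo sapiens) for cytotoxicity (a higher number here means a weaker inhibitor, a lower number a stronger inhibitor), compound 1 gives 3.9 ug/mL. Compound 2 `C=C1CC[C@H]2C(C)(C)CCC[C@]2(C)[C@H]1C/C=C1/CCOC1=O` has, in place of that aromatic ring, a five-membered non-aromatic ring with one hetero atom; in this assay compound 2 gives 19.2 ug/mL. The step of a 4.9-fold higher number from compound 1 to compound 2 (0.69 log units; beyond the scatter) shows that this swap weakens the cytotoxic effect. Compound 3 `C=C1[C@H](O)C[C@H]2C(C)(C)CCC[C@]2(C)[C@H]1/C=C/c1ccoc1` carries a 2-(furan-3-yl)ethenyl group and a hydroxy on a saturated ring carbon of the core; in this assay compound 3 gives 4.8 ug/mL, the second highest of the three numbers, within the scatter of compound 1 and well below compound 2.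

Compound 4 `C=C1CC[C@H]2C(C)(C)CCC[C@]2(C)[C@H]1/C=C/c1ccoc1` is compound 3 with hydrogen in place of hydroxy on a saturated ring carbon. For the measured compounds named here, no measured step concerns the removal of a hydroxy: the single step measured, from compound 1 to compound 2, changes the ring at the end of the arm, not this ring carbon. Compound 1 and compound 3 differ in several places, and their values lie within the scatter of each other. So no step beyond the scatter is expected in this assay, and a 1.0-fold higher number from compound 3 to compound 4 (0.02 log units; within the scatter) is the estimated change. Compound 4 is expected to give about 5 ug/mL, between 2 ug/mL and 12.5 ug/mL.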

Compound 4, half-maximal inhibitory concentration: 8 ug/mL
Compound 4: the middle estimate sits 1.6-fold (0.20 log units) below what was measured; measured number inside the range.
By their numbers in this assay, from the lowest: compounds 1, 3 and 4 (each within the scatter of the next, the first and the last beyond it); then compound 2.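

With hydrogen in place of hydroxy on a saturated ring carbon of the core, this assay gives a 1.7-fold higher number from compound 3 to compound 4 (0.22 log units; within the scatter), so the two compounds cannot be told apart here. For the compounds shown here, this is the first measured change at this ring carbon, and it shows that the hydroxy there is not needed for compound 4 to stay within the scatter of compound 3, whereas the change of ring at the end of the arm gave a 4.9-fold higher number from compound 1 to compound 2 (0.69 log units; beyond the scatter). Nothing is available that would explain why this ring carbon tolerates the loss of its hydroxy.

The compounds shown put only hydroxy and hydrogen on this ring carbon, so it remains open whether a methoxy group, an acetate ester or an amine there would also leave the number within the scatter. Going by these compounds alone, it is also open whether the non-aromatic ring of compound 2, placed on the arm of compound 4 instead of the furan-3-yl ring, would give a step of similar size to the one between compound 1 and compound 2.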